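The source may report more compounds than this note shows. Statements on the series, on what has been measured and on what is new or still open speak of the compounds shown alone.

Compound 1, `COc1ccc2c(c1)nc(/C=C/c1ccc(O)cc1)c(=O)n2CC(=O)O`, is the starting point of this small series. In a functional assay, with a stated time of 240 min, tested at 100 uM (on this read-out lower numbers stand for a weaker effect and higher numbers for a stronger effect at the one concentration tested), compound 1 gives 51.8%. Compound 2, `COc1ccc2c(c1)nc(/C=C/c1ccc(O)c(OC)c1)c(=O)n2CC(=O)O`, carries one added group; the change is methoxy in place of hydrogen on an aromatic carbon. In this assay compound 2 gives 74.9%, and the step of a number 23.1 percentage points higher from compound 1 to compound 2 (beyond the scatter) lies beyond the usual scatter of the measurement. Compound 3, `COc1ccc2nc(CCc3ccc(O)cc3)c(=O)n(CC(=O)O)c2c1`, is built on a different core, and the difference between the two cores is not broken down here. In this assay compound 3 gives 20.7%, the lowest of the three numbers, with gaps to compound 1 and to compound 2 that are both beyond the scatter. Compound 4, `COc1ccc2nc(CCc3ccc(O)c(OC)c3)c(=O)n(CC(=O)O)c2c1`, has not yet been measured. It arises from compound 3 by the change (methoxy in place of hydrogen on an aromatic carbon), the same change that turns compound 1 into compound 2, made at a place that is described in the same words. Because the earlier step was a number 23.1 percentage points higher from compound 1 to compound 2 (beyond the scatter), the expected step is a number 19.3 percentage points higher from compound 3 to compound 4 (beyond the scatter). Among the compounds with values here, that expectation is held cautiously, since only one earlier example of this change is available and it sits on another core. In this assay compound 4 is therefore estimated at 40%, with a likely range from 22% to 60%.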

Compound 4, a percentage reported as activity, at one concentration (the size of the read-out at that concentration, not a potency): 28.3%
Compound 4: the middle estimate sits 11.7 percentage points above what was measured; low and high end bracket the measured number.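

In this assay, adding the methoxy group gives a number 7.6 percentage points higher from compound 3 to compound 4 (within the scatter), so on this core the change from 4-hydroxyphenyl to 4-hydroxy-3-methoxyphenyl cannot be told apart from the ordinary spread of repeated measurements. Within the data shown here, the change therefore did not carry over from one core to the other at the same size: the same change on two cores in this assay, a number 23.1 percentage points higher (beyond the scatter) from compound 1 to compound 2 and a number 7.6 percentage points higher (within the scatter) from compound 3 to compound 4, 15.5 percentage points apart, beyond the scatter of two such steps This shows that a step seen on one core is not a safe guide to its size on the other, but with only two pairs it gives no general rule, and it does not show which feature of the two cores lies behind the gap.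

The compounds shown leave open how an ethoxy group or a chlorine atom would read at the same place on either core, and whether the methoxy step would look the same with an amine in place of the hydroxy group or an ester in place of the carboxylic acid. Going by these compounds, a read-out at one concentration is also not a potency, and how the two steps would look across a range of concentrations remains open.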